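A Methoxy Group in Place of Methyl

This account rests on a few compounds, and the source may have more. Where it says the series, first, only, none or still open, it means among the compounds named here.

In a functional assay on FM3A cells (Mus musculus) for antiproliferative activity (a higher number here means a weaker inhibitor, a lower number a stronger inhibitor), compound 1 `COc1cc(C(=O)c2sc(-c3ccsc3)cc2N)cc(OC)c1OC`, which carries a thiophen-3-yl group, gives 3.7 nM. Compound 2 `COc1cc(C(=O)c2sc(-c3ccc(F)cc3)cc2N)cc(OC)c1OC`, with a 4-fluorophenyl group instead, gives 16 nM, and compound 3 `COc1cc(C(=O)c2sc(-c3ccc(C)cc3)cc2N)cc(OC)c1OC`, with a 4-methylphenyl group, gives 16 nM. Compound 3 therefore stands level with compound 2, and the two share the highest number of the three.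

Compound 4 `COc1ccc(-c2cc(N)c(C(=O)c3cc(OC)c(OC)c(OC)c3)s2)cc1` keeps the shared core and differs from compound 3 in one group, 4-methylphenyl to 4-methoxyphenyl: methoxy in place of methyl on an aromatic carbon.

The measured step closest to this change is no change at the digits printed from compound 2 to compound 3 (within the scatter), which lies within the scatter and also exchanges one small group on the same aromatic carbon. The two modest steps, a 4.3-fold higher number from compound 1 to compound 2 (0.64 log units; beyond the scatter) and a 4.3-fold higher number from compound 1 to compound 3 (0.64 log units; beyond the scatter), both lie beyond the scatter, but they replace thiophen-3-yl, a change compound 4 does not add to compound 3. Within the data shown here, with a single comparable exchange, the evidence is thin, and no methoxy compound has yet been measured. No step beyond the scatter is therefore expected in this assay, and the expected change is a 1.1-fold lower number from compound 3 to compound 4 (0.06 log units; within the scatter). For compound 4 the estimated value is 14 nM, with an expected range from 5 nM to 40 nM.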

Compound 4, half-maximal inhibitory concentration: 31 nM
The estimate for compound 4 lay 2.2-fold (0.35 log units) below the measured number, within the range that was stated.
By their numbers in this assay, from the lowest: compound 1; then compounds 2, 3 and 4 (each within the scatter of the next).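

With compound 4, the para place on the six-membered aromatic ring now holds a third small group, and in this assay methoxy is not separated from methyl (a 1.9-fold higher number from compound 3 to compound 4 (0.29 log units; within the scatter)) or from fluoro (a 1.9-fold higher number from compound 2 to compound 4 (0.29 log units; within the scatter)). Fluoro, methyl and methoxy therefore cannot be told apart at this place, even though methoxy brings one more heavy atom than methyl and a hydrogen-bond acceptor that methyl lacks. The gap to the thiophen-3-yl compound does persist with the new group (an 8.4-fold higher number from compound 1 to compound 4 (0.92 log units; beyond the scatter)), so all three 4-substituted phenyl compounds lie beyond the scatter from compound 1, and nothing among the data gives a reason for these numbers.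

The compounds shown leave open whether a group of another kind at this place, such as an amine, a hydroxyl or a carboxylic acid, or a longer chain such as ethoxy or butoxy, would also stay within the scatter of compound 3. They also leave open whether an unsubstituted phenyl would stand with compound 1 or with the 4-substituted phenyl compounds.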